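This account rests on a few compounds, and the source may have more. Where it says the series, first, only, none or still open, it means among the compounds named here.

Going by the values given here, in a functional assay on SMMC-7721 cells (Homo sapiens) for inhibition, read by CCK-8 assay, with a stated time of 72 h, tested at 8 uM (a lower number here means less inhibition of growth, a higher number more inhibition of growth at the concentration tested), compound 1 (`Nc1ccccc1NC(=O)/C=C/c1ccc(CSc2cccc(F)c2)cc1`) gives 8.25%, the lower of the two numbers available so far. Among the compounds with values here, the only other measured compound, compound 2 (`Nc1ccccc1NC(=O)c1ccc(CSc2cccc(F)c2)cc1`), gives 83%, and that gap lies well beyond the usual scatter. Compound 3 (`Nc1ccccc1NC(=O)/C=C/c1ccc(CSCCc2ccccc2)cc1`) keeps the rest of compound 1 and changes one part: phenethyl in place of 3-fluorophenyl on a sulfur. Within the data shown here, both groups carry one six-membered aromatic ring of carbon only, and no measured pair yet shows what a swap on this sulfur does. The expectation therefore starts from compound 1 at 8.25%. The estimated step of a number 6.8 percentage points higher from compound 1 to compound 3 (within the scatter) is small and upward, most likely within the scatter, although a larger rise remains possible. Compound 3 is expected at about 15%, with an estimated range from 2% to 45%.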

Compound 3, percent growth inhibition at one concentration: 15.8%
Beside the measured number, compound 3's estimate is 0.8 percentage points below it; the range from low to high includes it.
By their numbers in this assay, from the lowest: compounds 1 and 3 (each within the scatter of the next); then compound 2.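

In this assay, the first step read on this sulfur is a number 7.6 percentage points higher from compound 1 to compound 3 (within the scatter), with phenethyl in place of 3-fluorophenyl. This gives the position its first measured swap: a group with a chain of saturated carbons before its aromatic ring and a group with the ring directly on the sulfur read alike at the concentration tested, so this one exchange does not separate the two compounds. No measurement shown gives a cause for this result.

As far as these compounds go, one swap says little about the whole position, so it remains open whether an amine, a carboxylic acid or a longer chain on this sulfur would move the number beyond the scatter. From the compounds shown here alone, it is also open whether phenethyl would read the same on the core of compound 2, which gives 83%.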